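Removing one methoxy from the core-attached ring of compound 1

This account rests on a few compounds, and the source may have more. Where it says the series, first, only, none or still open, it means among the compounds named here.

Measured so far:
- compound 1 `COc1cc(/C=C/C(=O)c2cc(-c3cc(OC)c(OC)c(OC)c3)n3nc(-c4ccccc4)cc3n2)cc(OC)c1OC`: 17900 nM
- compound 2 `COc1ccc(C(=O)/C=C/c2cc(-c3ccc(OC)c(OC)c3)n3nc(-c4ccccc4)cc3n2)cc1OC`: 7200 nM
- compound 3 `COc1ccc(-c2cc(/C=C/C(=O)c3ccc(OC)c(OC)c3)nc3cc(-c4ccccc4)nn23)cc1`: 16400 nM

All three values come from a functional assay on DU-145 cells (Homo sapiens) for antiproliferative activity, read by MTT assay, with a stated time of 24 h; a lower number here means a stronger inhibitor, a higher number a weaker inhibitor. Compound 1 gives the highest number of the three; its gap to compound 3 lies within the scatter, while compound 2 sits clearly lower, beyond the scatter.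

The next compound, compound 4 `COc1ccc(-c2cc(C(=O)/C=C/c3cc(OC)c(OC)c(OC)c3)nc3cc(-c4ccccc4)nn23)cc1OC`, differs from compound 1 in one place: hydrogen in place of methoxy on an aromatic carbon. Cut one bond further out, the change reads 3,4,5-trimethoxyphenyl to 3,4-dimethoxyphenyl on the ring attached to the shared core.

For the measured compounds named here, only one measured step removes a methoxy from an aromatic carbon: a 2.3-fold higher number from compound 2 to compound 3 (0.36 log units; beyond the scatter). That step sits on a different ring and a different position, so it is a loose guide at best. Going by the values given here, no measured pair isolates the present change on the core-attached ring.

Taking that step as the nearest precedent, compound 4 is expected to show a modest weakening, a 1.3-fold higher number from compound 1 to compound 4 (0.13 log units; within the scatter), with no change beyond the scatter fully possible. The estimate for compound 4 in this assay is 24000 nM, with a range from 10000 nM to 55000 nM.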

Compound 4, half-maximal inhibitory concentration: 14700 nM
For compound 4 the middle estimate is 1.6-fold (0.21 log units) above the measured one; the measured number falls inside the stated range.
By their numbers in this assay, from the lowest: compound 2; then compounds 4, 3 and 1 (each within the scatter of the next).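

In this assay, cutting 3,4,5-trimethoxyphenyl back to 3,4-dimethoxyphenyl on the ring attached to the shared core gives a 1.2-fold lower number from compound 1 to compound 4 (0.09 log units; within the scatter) and so stays within the scatter. This methoxy, ortho to a methoxy group on that ring, can therefore be replaced by hydrogen with no readable shift in this read-out, whereas the earlier pair gave a 2.3-fold higher number from compound 2 to compound 3 (0.36 log units; beyond the scatter) for the same formal change. Hydrogen in place of methoxy on an aromatic carbon thus does not behave as one transferable step in this series, since the two pairs give clearly separate readings: the same change on two cores in this assay, a 2.3-fold higher number (0.36 log units; beyond the scatter) from compound 2 to compound 3 and a 1.2-fold lower number (0.09 log units; within the scatter) from compound 1 to compound 4, 2.8-fold (0.44 log units) apart, beyond the scatter of two such steps.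

The compounds shown leave open whether this aromatic carbon accepts groups other than methoxy and hydrogen, such as hydroxy, fluorine, an amine or a longer alkoxy chain, and whether any of these would move the number beyond the scatter. They also leave open what happens when the remaining methoxy groups of the 3,4-dimethoxyphenyl ring are removed or replaced, with the rest of compound 4 held fixed.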